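The compounds below may be only part of what the source reports. "The series", "measured", "known", "first", "only" and "open" are said of these compounds alone.

Three compounds of the shared core carry different groups at the same aromatic carbon. Compound 1 `CC(C)CCc1ccc2c(NCCCNCc3ccco3)ccnc2c1` gives 11200 nM in an ADME assay on HepG2 cells (Homo sapiens) for cytotoxicity, read by luminescence, CellTiter-Glo and ATP content, with a stated time of 72 h; a higher number here means that more compound is needed for the effect, a lower number that less compound is needed. Compound 2 `Fc1ccc(Cc2ccc3c(NCCCNCc4ccco4)ccnc3c2)c(Cl)c1` gives 5730 nM in this assay, and compound 3 `COc1ccc(Oc2ccc3c(NCCCNCc4ccco4)ccnc3c2)cc1` gives 5300 nM. Compound 3 has the lowest number of the three, but the gap to compound 2 is within the scatter, so the two are not separated; only the gap to compound 1 is beyond it, a modest step of a 2.1-fold lower number from compound 1 to compound 3 (0.32 log units; beyond the scatter). The step of a 2.0-fold lower number from compound 1 to compound 2 (0.29 log units; within the scatter) is within the scatter, as is a 1.1-fold lower number from compound 2 to compound 3 (0.03 log units; within the scatter).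

Compound 4 `c1coc(CNCCCNc2ccnc3cc(-c4cccc5ccccc45)ccc23)c1` is not yet measured in this assay. It differs from compound 3 in one place: naphthalen-1-yl in place of 4-methoxyphenoxy on an aromatic carbon. Both earlier exchanges of an alkyl chain for an aromatic group, a 2.0-fold lower number from compound 1 to compound 2 (0.29 log units; within the scatter) and a 2.1-fold lower number from compound 1 to compound 3 (0.32 log units; beyond the scatter), gave small reductions, while the exchange of one aromatic group for another, a 1.1-fold lower number from compound 2 to compound 3 (0.03 log units; within the scatter), changed nothing beyond the scatter. The closest analogy is the last one, so for compound 4 a step no larger than the scatter is expected, a 1.2-fold lower number from compound 3 to compound 4 (0.07 log units; within the scatter). Compound 4 is estimated at 4500 nM, with a range of 1800 nM to 11000 nM.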

Compound 4, half-maximal effective concentration: 5600 nM
The estimate for compound 4 lay 1.2-fold (0.09 log units) below the measured number; measured number inside the range.
By their numbers in this assay, from the lowest: compounds 3, 4, 2 and 1 (each within the scatter of the next, the first and the last beyond it).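

At this aromatic carbon, naphthalen-1-yl, with its two six-membered aromatic rings of carbon only and no hydrogen-bond acceptors, does not separate from 4-methoxyphenoxy in this assay (a 1.1-fold higher number from compound 3 to compound 4 (0.02 log units; within the scatter)), so neither the ether-linked ring nor its hydrogen-bond acceptors are needed to hold the number at this level. Among the compounds shown here, the directly ring-bound group is equally unseparated from the 2-chloro-4-fluorobenzyl group (a 1.0-fold lower number from compound 2 to compound 4 (0.01 log units; within the scatter)) and from isopentyl (a 2.0-fold lower number from compound 1 to compound 4 (0.30 log units; within the scatter)), both steps printed as within the scatter, which leaves compound 3 against compound 1 as the only pair in the set beyond it. Nothing measured accounts for this flat response.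

From the compounds shown here alone, whether an amine or a carboxylic acid at this carbon would move the number beyond the scatter remains open. So does whether changes elsewhere on the shared core would matter more than changes here.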